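A few compounds are considered here, and "the series" means these few. Any claim that something is new, unique, unknown or untested is made for them only; others in the source may bear on it.

In a functional assay on VCaP cells (Homo sapiens) for antiproliferative activity, read by CCK-8 assay, with a stated time of 6 days (a lower number here means a stronger inhibitor, a higher number a weaker inhibitor), three compounds share one core and differ only in the ring on the amine nitrogen. Compound 1 `C[C@@H](Cn1ccc(-c2ccc(C#N)c(Cl)c2)n1)Nc1ccccc1` carries phenyl there. Compound 1 gives > 30000 nM, which is a limit of the assay and not a measured number. Compound 2 `C[C@@H](Cn1ccc(-c2ccc(C#N)c(Cl)c2)n1)Nc1ccncc1`, with pyridin-4-yl, gives 9900 nM. Compound 3 `C[C@@H](Cn1ccc(-c2ccc(C#N)c(Cl)c2)n1)Nc1ncccn1`, with pyrimidin-2-yl, gives 480 nM, the lowest number of the three. The ring swaps produced an at least 3.0-fold lower number from compound 1 to compound 2 (0.48 log units; beyond the scatter), then an at least 62-fold lower number from compound 1 to compound 3 (1.79 log units; beyond the scatter), and also a 21-fold lower number from compound 2 to compound 3 (1.31 log units; beyond the scatter).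

Compound 4 `Cc1ccnc(N[C@@H](C)Cn2ccc(-c3ccc(C#N)c(Cl)c3)n2)n1` keeps all of compound 3 except for one small edit: methyl in place of hydrogen on an aromatic carbon. This places methyl in place of hydrogen on an aromatic carbon, turning pyrimidin-2-yl into 4-methylpyrimidin-2-yl. The three measured steps bear on it only indirectly, since each replaces a whole ring and none adds a methyl. They show that this ring can move the number a long way, as in a 21-fold lower number from compound 2 to compound 3 (1.31 log units; beyond the scatter), so even a small edit here may matter. The ring type stays the same, however, so a far smaller shift is expected, with a slight weakening somewhat more likely than a gain. That reasoning gives an expected 1.3-fold higher number from compound 3 to compound 4 (0.10 log units; within the scatter). For compound 4 the estimated value in this assay is 600 nM, with an expected range from 150 nM to 2500 nM.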

Compound 4, half-maximal inhibitory concentration: 850 nM
Compound 4: the middle estimate sits 1.4-fold (0.15 log units) below what was measured; low and high end bracket the measured number.
By their numbers in this assay, from the lowest: compounds 3 and 4 (each within the scatter of the next); then compound 2. At a limit, above all of these: compound 1.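

In this assay, the step of a 1.8-fold higher number from compound 3 to compound 4 (0.25 log units; within the scatter) shows that a methyl on this aromatic carbon, next to the ring nitrogen, leaves a number that cannot be told apart from that of the unsubstituted pyrimidin-2-yl compound, something the earlier whole-ring swaps could not show. The large advantage over the pyridin-4-yl compound also survives the added methyl, with a 12-fold lower number from compound 2 to compound 4 (1.07 log units; beyond the scatter), so in these compounds that advantage is not confined to the bare pyrimidin-2-yl ring. Against the phenyl compound the step reads an at least 35-fold lower number from compound 1 to compound 4 (1.54 log units; beyond the scatter), and the value of compound 1 is a limit and not a measured number: the limit of > 30000 nM in this assay, at which 1 of the 4 values shown sits.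

On these data alone, a single methyl at a single position does not reveal how much room this carbon offers, so it remains open whether an ethyl, a methoxy, a trifluoromethyl or an amine here would stay within the scatter of compound 3 or move the number well away from it. As far as these compounds go, it is also open whether a methyl on another carbon of the ring, as in 5-methylpyrimidin-2-yl, would be tolerated in the same way.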